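This account rests on a few compounds, and the source may have more. Where it says the series, first, only, none or still open, it means among the compounds named here.

Compounds measured in an assay on isolated protein for inhibition of Rho-associated protein kinase 1 (Homo sapiens), read by scintillation counting, radiometric assay and 33P incorporation, with a stated time of 40 min, in the presence of a further agent that is not named here (on this read-out higher numbers stand for weaker inhibition and lower numbers for stronger inhibition), so far:

compound 1, `CCCC(=O)Nc1cccc(NC(=O)COc2ccc3c(=O)ccoc3c2)c1`, 1430 nM
compound 2, `O=C(COc1ccc2c(=O)ccoc2c1)Nc1cccc(NC(=O)c2ccccc2)c1`, 120 nM

Compound 2 gives the lowest of the two numbers in this assay; its nearest neighbour is compound 1, whose value lies a 12-fold lower number from compound 1 to compound 2 (1.08 log units; beyond the scatter) step away, a large step that comes from putting phenyl in place of propyl on a carbonyl carbon.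

Compound 3, `CCc1ccc(C(=O)Nc2cccc(NC(=O)COc3ccc4c(=O)ccoc4c3)c2)cc1`, is still to be measured in this assay. Against compound 2 it carries one change, (ethyl in place of hydrogen on an aromatic carbon), which cut one bond further out reads phenyl to 4-ethylphenyl. Among the measured compounds shown here, no measured pair varies a substituent on this phenyl, so the only step that bears on it is the one from compound 1 to compound 2, and that step concerns the whole group on the carbonyl carbon rather than a substituent on it. Going from phenyl to 4-ethylphenyl is a smaller alteration than propyl to phenyl, and for compound 3 a step of a 1.3-fold higher number from compound 2 to compound 3 (0.10 log units; within the scatter) is expected, most likely within the scatter. The estimate for compound 3 in this assay is 150 nM, with a range from 40 nM to 600 nM.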

Compound 3, half-maximal inhibitory concentration: 235 nM
Beside the measured number, compound 3's estimate is 1.6-fold (0.19 log units) below it; the measured number falls inside the stated range.
By their numbers in this assay, from the lowest: compounds 2 and 3 (each within the scatter of the next); then compound 1.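

In this assay, ethyl in place of hydrogen on an aromatic carbon of the phenyl, para to a large group, gives a step that stays inside the scatter (a 2.0-fold higher number from compound 2 to compound 3 (0.29 log units; within the scatter)), so this position takes a group of 2 heavy atoms with no change that can be told from repeat measurement. The step from the propyl amide also holds with the substituted ring (a 6.1-fold lower number from compound 1 to compound 3 (0.78 log units; beyond the scatter)), so the lower number seen with phenyl (a 12-fold lower number from compound 1 to compound 2 (1.08 log units; beyond the scatter)) is not confined to the unsubstituted phenyl among these compounds. No accompanying data bear on what lies behind any of these steps.

From the compounds shown here alone, one ethyl group at one place gives no trend, so it remains open whether the same tolerance extends to a longer chain such as butyl, to a methoxy group, or to an amine or a carboxylic acid at this position. Also open, going by these compounds, are other places on the same ring and the replacement of the phenyl itself by a pyridyl ring or a saturated ring such as cyclohexyl.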